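Adding dimethylamino to compound 1

This account rests on a few compounds, and the source may have more. Where it says the series, first, only, none or still open, it means among the compounds named here.

Compound 1 `O=C1Nc2ccccc2/C1=N/NC(=S)Nc1ccccc1` (1470 nM)
Compound 2 `O=C1Nc2ccccc2/C1=N/NC(=S)NCc1ccccc1` (7630 nM)
Compound 3 `COc1ccccc1NC(=S)N/N=C1\C(=O)Nc2ccccc21` (2690 nM)

In a functional assay on KB-V1 cells (Homo sapiens) for cytotoxicity, read by MTT assay, with a stated time of 72 h (a higher number here means a weaker inhibitor, a lower number a stronger inhibitor), compound 1 gives 1470 nM and cannot be told apart from compound 3 at 2690 nM while compound 2 stands apart (a 5.2-fold higher number from compound 1 to compound 2 (0.72 log units; beyond the scatter)). Compound 4 `CN(C)c1ccc(NC(=S)N/N=C2\C(=O)Nc3ccccc32)cc1` differs from compound 1 in one place (dimethylamino in place of hydrogen on an aromatic carbon): dimethylamino in place of hydrogen on an aromatic carbon, para to a large group. The closest measured change is methoxy in place of hydrogen (a 1.8-fold higher number from compound 1 to compound 3 (0.26 log units; within the scatter)), also made on an aromatic carbon. The benzyl change is of another kind and bears less on this one. A small move to a higher number, probably within the scatter, is therefore expected in this assay here. The estimated step (a 1.5-fold higher number from compound 1 to compound 4 (0.18 log units; within the scatter)) is small. Compound 4 is estimated at 2200 nM with an expected range from 800 nM to 6000 nM in this measurement.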

Compound 4, half-maximal inhibitory concentration: 2320 nM
The estimate for compound 4 lay 1.1-fold (0.02 log units) below the measured number, within the range that was stated.
By their numbers in this assay, from the lowest: compounds 1, 4 and 3 (each within the scatter of the next); then compound 2.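

Placing dimethylamino on an aromatic carbon, para to a large group, brings a 1.6-fold higher number from compound 1 to compound 4 (0.20 log units; within the scatter) in this assay. Compound 1 and compound 4 therefore cannot be told apart, which shows that this place on the ring can carry a group of three heavy atoms with no clear loss of cytotoxicity. No measurement is available to explain this result. Still open, going by these compounds, is whether a carboxylic acid at this place would also leave the number within the scatter. The same question applies to a longer amine such as diethylamino.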